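The source may report more compounds than this note shows. Statements on the series, on what has been measured and on what is new or still open speak of the compounds shown alone.

Three compounds carry a (4-methylphenyl)amino or (2-methylphenyl)amino group on a nitrogen on an aromatic ring. Compound 1 `Cc1ccccc1Nc1nc(C)c(C(=O)/C=C/c2ccc(Cl)cc2)s1` and compound 2 `Cc1ccc(Nc2nc(C)c(C(=O)/C=C/c3ccc(Cl)cc3)s2)cc1` share one core, while compound 3 `COc1cc(/C=C/C(=O)c2sc(Nc3ccc(C)cc3)nc2C)cc(OC)c1OC` has another; the difference between the core of compound 3 and that of compound 2 is not broken down here. In a functional assay on Bel-7402 cells (Homo sapiens) for cytotoxicity, read by MTT assay (a higher number here means a weaker inhibitor, a lower number a stronger inhibitor), compound 1 gives > 25000 nM, which is a limit of the assay rather than a number. Compound 2 also reaches only a limit in this assay, > 25000 nM. Compound 3 likewise gives only a limit in this assay, > 25000 nM. The change from compound 2 to compound 1, (2-methylphenyl in place of 4-methylphenyl on a nitrogen on an aromatic ring), therefore made a step that cannot be read, a step that the two limits leave unreadable from compound 2 to compound 1, since both ends sit at the limit of > 25000 nM in this assay, at which 3 of the 3 values shown sit. Compound 4 `COc1cc(/C=C/C(=O)c2sc(Nc3ccccc3C)nc2C)cc(OC)c1OC` is not yet measured and differs from compound 3 by the same change, (2-methylphenyl in place of 4-methylphenyl on a nitrogen on an aromatic ring). The step from compound 3 to compound 4 is expected to be a step that the limit leaves unreadable from compound 3 to compound 4 because the same change earlier read a step that the two limits leave unreadable from compound 2 to compound 1, with nothing here pointing to a gain. Compound 4 is thus estimated at about 40000 nM in this assay, between 20000 nM and 120000 nM, most likely again only as a limit.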

Compound 4, half-maximal inhibitory concentration: 10300 nM
The estimate for compound 4 lay 3.9-fold (0.59 log units) above the measured number; measured number below the stated range.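

In this assay, going by these compounds, putting 2-methylphenyl in place of 4-methylphenyl on the nitrogen gives an at least 2.4-fold lower number from compound 3 to compound 4 (0.38 log units; beyond the scatter), so on this core the change lowers the number, and the true size of the step stays unknown as the starting point is only a limit of the assay. On the core shared by compound 1 and compound 2 the same change cannot be read, so this one pair does not show that the change carries from one core to the other, only that it works on one of them: the limit of > 25000 nM in this assay, at which 3 of the 4 values shown sit. The pair also gives the direction of a change and no reason for it.

Still open, on these data alone, is whether a 2-ethylphenyl or 2-chlorophenyl group on that nitrogen would lower the number further on the core of compound 4. Also open, as far as these compounds go, is whether the lower number of compound 4 would hold in other cell lines.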